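This account rests on a few compounds, and the source may have more. Where it says the series, first, only, none or still open, it means among the compounds named here.

Measured compounds: compound 1 `COc1cc2c(Oc3ccc(NC(=O)c4nn(-c5ccccc5)c(=O)cc4C)cc3F)ccnc2cc1OCCCN1CCCC1`, compound 2 `COc1cc2c(Oc3ccc(NC(=O)c4nn(-c5ccccc5)c(=O)cc4C)cc3F)ccnc2cc1OCCCN1CCCCC1`, compound 3 `COc1cc2c(Oc3ccc(NC(=O)c4nn(-c5ccccc5)c(=O)cc4C)cc3F)ccnc2cc1OCCCN1CCN(C)CC1`.

In a functional assay on A549 cells (Homo sapiens) for inhibition, read by MTT assay, with a stated time of 72 h (a lower number here means a stronger inhibitor, a higher number a weaker inhibitor), compound 1 gives 370 nM, compound 2 gives 150 nM, and compound 3 gives 350 nM. Compound 1 has the highest of the three numbers, separated from compound 2 by a 2.5-fold lower number from compound 1 to compound 2 (0.39 log units; beyond the scatter) but from compound 3 only by a 1.1-fold lower number from compound 1 to compound 3 (0.02 log units; within the scatter), and a 2.3-fold higher number from compound 2 to compound 3 (0.37 log units; beyond the scatter) completes the set. Compound 4 `COc1cc2c(Oc3ccc(NC(=O)c4nn(-c5ccccc5OC(F)(F)F)c(=O)cc4C)cc3F)ccnc2cc1OCCCN1CCCC1` differs from compound 1 by trifluoromethoxy in place of hydrogen on an aromatic carbon, ortho to a large group. All three measured steps change only the amine at the end of the chain, so none of them bears on this change. Compound 4 is therefore expected to show a 1.1-fold higher number from compound 1 to compound 4 (0.03 log units; within the scatter), with a wide range, and its estimate in this assay is 400 nM (range 130 nM to 1300 nM).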

Compound 4, half-maximal inhibitory concentration: 140 nM
Compound 4: middle estimate off by 2.9-fold (0.46 log units), on the high side; low and high end bracket the measured number.
By their numbers in this assay, from the lowest: compounds 4 and 2 (each within the scatter of the next); then compounds 3 and 1 (each within the scatter of the next).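

Putting trifluoromethoxy on the phenyl ring, on an aromatic carbon ortho to a large group, gives a 2.6-fold lower number from compound 1 to compound 4 (0.42 log units; beyond the scatter) in this assay. The earlier steps shown here changed only the amine, so this shows that a change at this far end of compound 1 can also move the number beyond the scatter. Nothing measured here explains the drop. Still open, as far as these compounds go, is whether a smaller group such as methoxy or a single fluorine on the same carbon does the same, and whether trifluoromethoxy combined with the piperidin-1-yl amine lowers the number further.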